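Swapping the Bromophenyl Sulfide Arm for a Small Ring

This account rests on a few compounds, and the source may have more. Where it says the series, first, only, none or still open, it means among the compounds named here.

Compound 1 `Cc1cc(Nc2cc(-c3ccccc3)[nH]n2)n2nc(SCc3cccc(Br)c3)nc2n1` is the weakest of the three measured compounds in a functional assay on PC-9 cells (Homo sapiens) for inhibition, read by MTT assay, with a stated time of 72 h (on this read-out lower numbers stand for stronger inhibition and higher numbers for weaker inhibition), where compound 1 gives 8900 nM. Compound 2 `Cc1cc(Nc2cc(-c3ccc(Cl)cc3)[nH]n2)n2nc(SCc3ccc(Br)cc3)nc2n1` gives 4920 nM in this assay, a number that lies within the scatter of compound 1. Compound 3 `Cc1cc(Nc2ccn(Cc3csc4ccc(Cl)cc34)n2)n2nc(SCc3ccc(Br)cc3)nc2n1` gives 4350 nM in this assay, a gap to compound 1 that lies just beyond the scatter. Among the measured compounds shown here, none of these three differs from another in one place alone, so no single step between measured compounds can be read.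

Compound 4 `Cc1cc(Nc2cc(-c3ccccc3)[nH]n2)n2nc(SCC3CC3)nc2n1` is the untested compound. It differs from compound 1 in one place: cyclopropyl in place of 3-bromophenyl on a saturated chain carbon bound to a sulfur. The group that leaves is the only one of its kind in the series, and every measured compound carries a bromophenyl on the sulfur-bound chain, so nothing in the data speaks directly to removing it.

With the aromatic ring gone from that arm, the author expects the number for compound 4 in this assay to move toward weaker inhibition by a modest amount, a step from compound 1 to compound 4 of a 1.6-fold higher number from compound 1 to compound 4 (0.20 log units; within the scatter), close to or slightly beyond the scatter. For compound 4 the estimate is 14000 nM, with a range from 4500 nM to 45000 nM.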

Compound 4, half-maximal inhibitory concentration: > 50000 nM
Compound 4 ended at the assay's limit; the forecaster's own chance of this, stated with the estimate: 10%; middle value at least 3.5-fold (0.55 log units) away from the limit.
By their numbers in this assay, from the lowest: compounds 3, 2 and 1 (each within the scatter of the next, the first and the last beyond it). At a limit, above all of these: compound 4.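

In this assay compound 4 gives > 50000 nM, which is a limit of the assay and not a number. Cyclopropyl in place of 3-bromophenyl on a saturated chain carbon bound to a sulfur gives an at least 5.6-fold higher number from compound 1 to compound 4 (0.74 log units; beyond the scatter), so this position is not indifferent to the group it holds, and this change is not one the read-out tolerates. Among the compounds shown here, all of the earlier compounds carried a bromophenyl there. They left this position unread. The step gives only a lower bound on the loss and not its full size: the limit of > 50000 nM in this assay, at which 1 of the 4 values shown sits.

What the compounds shown leave open is which part of the change counts, since the bromine, the aromatic ring and the number of heavy atoms all change together in this one step. An unsubstituted phenyl on the same chain carbon would part the bromine from the aromatic ring, while a cyclohexyl ring or a longer chain such as n-butyl would show whether a larger carbon group without an aromatic ring can take the place of 3-bromophenyl.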